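The compounds below may be only part of what the source reports. "The series", "measured", "known", "first", "only" and "open" are said of these compounds alone.

Measured so far in a functional assay on MCF7 cells (Homo sapiens) for antiproliferative activity, read by MTT assay, with a stated time of 72 h; on this read-out lower numbers stand for stronger inhibition and higher numbers for weaker inhibition
compound 1 `CC/C=C/C(=O)Nc1cccc(Oc2nc(Nc3cccc(OC)c3)nc3c2CSCC3)c1` gives 24200 nM
compound 2 `C=CC(=O)Nc1cccc(Oc2nc(Nc3cccc(C#N)c3)nc3c2CSCC3)c1` gives 21700 nM

Compound 2 at 21700 nM lies within the scatter of compound 1, so neither ranks ahead. Compound 3 `CC/C=C/C(=O)Nc1cccc(Oc2nc(Nc3cccc(C#N)c3)nc3c2CSCC3)c1` differs from compound 2 by but-1-en-1-yl in place of vinyl on a carbonyl carbon with but-1-en-1-yl in place of vinyl on a carbonyl carbon. Among the compounds with values here, no measured pair shows this change alone. Compound 1 already bears but-1-en-1-yl, differs elsewhere too, and gives 24200 nM in the same range. No shift beyond the scatter is expected in this assay (estimated a 1.1-fold higher number from compound 2 to compound 3 (0.03 log units; within the scatter)). The estimate for compound 3 is 23000 nM (expected range 10000 nM to 45000 nM).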

Compound 3, half-maximal inhibitory concentration: 15900 nM
For compound 3 the middle estimate is 1.4-fold (0.16 log units) above the measured one; the range from low to high includes it.
By their numbers in this assay, from the lowest: compounds 3, 2 and 1 (each within the scatter of the next).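

In this assay, the exchange on the carbonyl carbon can now be read as a matched pair: with but-1-en-1-yl in place of vinyl, the result is (a 1.4-fold lower number from compound 2 to compound 3 (0.14 log units; within the scatter)). Cyano in place of methoxy on an aromatic carbon can also now be read alone (a 1.5-fold lower number from compound 1 to compound 3 (0.18 log units; within the scatter)), so neither single change separates these compounds. Nothing at hand accounts for either step.

Going by these compounds, it stays open whether a longer chain or an amine in place of but-1-en-1-yl on the carbonyl carbon would give a step beyond the scatter. The same question holds for a carboxylic acid in place of cyano on the aromatic carbon.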